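This account rests on a few compounds, and the source may have more. Where it says the series, first, only, none or still open, it means among the compounds named here.

Compound 3, `CS(=O)(=O)c1ccc(C2=NN(c3ccc(S(N)(=O)=O)cc3)C(c3ccc(Cl)cc3)C2)cc1`, carries a 4-chlorophenyl group on a saturated ring carbon of its core and a sulfamoyl group on one of its aromatic rings. In a functional assay on the whole organism for inhibition, with Rattus norvegicus as the target, read by paw edema, with a stated time of 3 h, at a dose of 50 mg/kg by the oral route (a higher number here means more inhibition at the dose given (going by the name of the read-out), a lower number less inhibition), compound 3 gives 42.4%. Compound 1, `CS(=O)(=O)c1ccc(C2=NN(c3ccc(C(=O)O)cc3)C(c3ccc(F)cc3)C2)cc1`, gives 42.3% in this assay, and compound 2, `CS(=O)(=O)c1ccc(C2=NN(c3ccc(C(=O)O)cc3)C(c3ccc(Cl)cc3)C2)cc1`, gives 50.4%. All three numbers sit within the usual scatter of one another, so compound 3 is neither clearly weaker nor clearly stronger than compound 1 or compound 2.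

Compound 4, `COc1ccc(C2CC(c3ccc(S(C)(=O)=O)cc3)=NN2c2ccc(S(N)(=O)=O)cc2)cc1OC`, differs from compound 3 in one place: 3,4-dimethoxyphenyl in place of 4-chlorophenyl on a saturated ring carbon. The aromatic ring on that saturated ring carbon has been exchanged once before among the measured compounds, in the move from fluoro to chloro, which gave a number 8.1 percentage points higher from compound 1 to compound 2 (within the scatter). The other measured step, sulfamoyl in place of carboxy, gave a number 8 percentage points lower from compound 2 to compound 3 (within the scatter) and does not touch this position at all. Among the compounds with values here, neither measured step moved the number beyond the scatter, and no measured compound carries a 3,4-dimethoxyphenyl group, so there is nothing to suggest a large shift in either direction.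

For compound 4 the expected step is therefore a number 0.4 percentage points lower from compound 3 to compound 4 (within the scatter), no more than the scatter. Compound 4 is estimated to give 42% in this assay, expected to fall between 25% and 58%.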

Compound 4, a percentage reported as inhibition, in the whole organism at one dose (the size of the read-out at that dose, not a potency): 45.5%
For compound 4 the middle estimate is 3.5 percentage points below the measured one, within the range that was stated.
By their numbers in this assay, from the lowest: compounds 1, 3, 4 and 2 (each within the scatter of the next).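

On this saturated ring carbon, 3,4-dimethoxyphenyl, with 10 heavy atoms and 2 hydrogen-bond acceptors, replaces 4-chlorophenyl, with 7 heavy atoms and 0 acceptors, and in this assay this gives a number 3.1 percentage points higher from compound 3 to compound 4 (within the scatter). The earlier change at this carbon only exchanged one halogen for another, whereas this one removes the chlorine and brings in two methoxy groups, and the number still stays within the scatter. Nothing measured here speaks to the reason for this result.

As far as these compounds go, it remains open whether a different kind of group on this carbon, such as a ring bearing a dimethylamino group, a carboxylic acid or a plain butyl chain in place of the aromatic ring, would move the number beyond the scatter. Also open, from the compounds shown here alone, is whether 3,4-dimethoxyphenyl would give a similar number with the carboxy group of compound 2 in place of the sulfamoyl group of compound 4.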